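A few compounds are considered here, and "the series" means these few. Any claim that something is new, unique, unknown or untested is made for them only; others in the source may bear on it.

Compounds measured so far in an ADME assay on L929 cells (Mus musculus) for cytotoxicity, read by resazurin assay, with a stated time of 72 h; on this read-out lower numbers stand for stronger inhibition and higher numbers for weaker inhibition:

compound 1 `O=C(/C=C/c1ccc2c(c1)B(O)OC2)c1ccc(Cl)c(Cl)c1`: > 10 ug/mL
compound 2 `O=C(/C=C/c1ccc2c(c1)B(O)OC2)c1ccc(O)cc1`: > 10 ug/mL
compound 3 `O=C(/C=C/c1ccc2c(c1)B(O)OC2)c1ccc(F)cc1`: > 10 ug/mL

Each of these three values is a limit of this assay and not a number. Compound 3 therefore stands only at the limit of > 10 ug/mL in this assay, at which 3 of the 3 values shown sit, with no number of its own.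

Compound 4 `O=C(/C=C/c1ccc2c(c1)B(O)OC2)c1ccc(Cl)cc1` differs from compound 3 by chloro in place of fluoro on an aromatic carbon.

For the measured compounds named here, the only measured single-point step, a step that the two limits leave unreadable from compound 2 to compound 3, is itself unreadable, so no step of known size bears on this change. Nothing beyond the scatter is expected in this assay, and a limit is the most likely outcome. Compound 4 is estimated at 15 ug/mL, with a range from 7 ug/mL to 40 ug/mL. This estimate means an expected step that the limit leaves unreadable from compound 3 to compound 4.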

Compound 4, half-maximal inhibitory concentration: > 10 ug/mL
Compound 4 gave a limit, no number; the forecaster's own chance of this, stated with the estimate: 80%; the middle value does not contradict the limit.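

The steps to compound 4 from compound 1, compound 2 and compound 3 cannot be read, because all four values are limits: the limit of > 10 ug/mL in this assay, at which 4 of the 4 values shown sit. The compounds shown leave open whether any of these ring substituents on the shared core changes cytotoxicity at all.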